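Amine substituent variation on a shared core

The source may hold more compounds than are shown below. What is called first, only, known or untested is meant among the compounds shown, and "the series" means these compounds.

Measured compounds in a functional assay on MCF7 cells (Homo sapiens) for inhibition, read by MTT assay, with a stated time of 72 h; a lower number here means a stronger inhibitor, a higher number a weaker inhibitor:
compound 1 `OCCNc1nnc2nncn2n1` — 11600 nM
compound 2 `CN(C)c1nnc2nncn2n1` — 7760 nM

Compound 1 stands with the highest of the two numbers in this assay; its nearest neighbour is compound 2, and the step of a 1.5-fold lower number from compound 1 to compound 2 (0.17 log units; within the scatter) lies within the scatter, so the two compounds cannot be ordered on these data. That step swaps dimethylamino for (2-hydroxyethyl)amino on an aromatic carbon.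

Compound 3 `c1nnc2nnc(NC3CCCC3)nn12` differs from compound 1 as follows: cyclopentyl in place of 2-hydroxyethyl on a nitrogen on an aromatic ring

Among the measured compounds shown here, only the step from compound 1 to compound 2 bears on this change, and it is the sole measured step. It removed the 2-hydroxyethyl chain in favour of two methyl groups without a step beyond the scatter. The change to cyclopentyl likewise removes the 2-hydroxyethyl group, but the entering group is larger and carries a ring, for which no measured comparison exists.

Compound 3 is therefore expected near compound 1, with a number of 8500 nM in this assay, ranging from 3000 nM to 25000 nM. Relative to compound 1 this expectation amounts to a 1.4-fold lower number from compound 1 to compound 3 (0.14 log units; within the scatter), not beyond the scatter.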

Compound 3, half-maximal inhibitory concentration: 88200 nM
Estimate against measurement, compound 3: 10-fold (1.02 log units) below; measured number outside the range, above it.
By their numbers in this assay, from the lowest: compounds 2 and 1 (each within the scatter of the next); then compound 3.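

Working notes on the nitrogen on an aromatic ring, in this assay: replacing 2-hydroxyethyl with cyclopentyl gives a 7.6-fold higher number from compound 1 to compound 3 (0.88 log units; beyond the scatter), so this is the first change at this position to move the number beyond the scatter, and it moves towards a weaker inhibitor. Loss of the 2-hydroxyethyl group alone does not go with such a step, since the other change that removes it gives a 1.5-fold lower number from compound 1 to compound 2 (0.17 log units; within the scatter); what sets the cyclopentyl change apart on these compounds is the entering group, a five-membered non-aromatic ring of carbon only, with no hydrogen-bond donor or acceptor. Nothing available explains the rise in the number, and the series gives no measured property of these groups that bears on it.

On these data alone, whether the step follows the ring itself or the all-carbon make-up of the entering group stays open. A straight pentyl chain would test the ring, and a tetrahydropyranyl group, which keeps a ring and brings back an oxygen, would test the all-carbon make-up, each on the shared core.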